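Amino in place of aryl on the carbonyl carbon

This account rests on a few compounds, and the source may have more. Where it says the series, first, only, none or still open, it means among the compounds named here.

Of the compounds shown here, three have numbers so far. In a functional assay on M14 cells (Homo sapiens) for inhibition, read by sulforhodamine B assay, with a stated time of 48 h (a higher number here means a weaker inhibitor of growth, a lower number a stronger inhibitor of growth), compound 1 `O=C(Nc1cccc(-n2cc(-c3ccncc3)c(-c3ccc(Cl)c(O)c3)n2)c1)Nc1ccc(Cl)c(Cl)c1` gives 1180 nM, compound 3 `O=C(Nc1cccc(-n2cc(-c3ccncc3)c(-c3ccc(Cl)c(O)c3)n2)c1)Nc1cc(C(F)(F)F)cc(C(F)(F)F)c1` gives 607 nM, and compound 2 `COc1cc(-c2nn(-c3cccc(NC(=O)c4ccc(Cl)c(C(F)(F)F)c4)c3)cc2-c2ccncc2)ccc1Cl` gives 2790 nM. Compound 2 thus stands highest of the three: compound 1 is its nearest neighbour, with a number lower beyond the scatter, and compound 3 lies furthest, also lower beyond the scatter. Within the data shown here, no two measured compounds differ in a single place, so no counted step is available itself.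

Compound 4 `COc1cc(-c2nn(-c3cccc(NC(=O)Nc4ccc(Cl)c(C(F)(F)F)c4)c3)cc2-c2ccncc2)ccc1Cl` is not yet measured. It differs from compound 2 in one place: (4-chloro-3-(trifluoromethyl)phenyl)amino in place of 4-chloro-3-(trifluoromethyl)phenyl on a carbonyl carbon. The amino group that enters on the carbonyl carbon is present in compounds 1 and 3, both with lower numbers than compound 2, while compound 2 lacks it; the cores of compounds 1 and 3 differ from that of compound 2 as well, so the comparison is indirect. On that basis the expected step in this assay is a 2.8-fold lower number from compound 2 to compound 4 (0.45 log units; beyond the scatter), downward and beyond the scatter but moderate. The estimate for compound 4 in this assay is 1000 nM, with a range from 400 nM to 2800 nM.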

Compound 4, concentration for 50% growth inhibition: 1080 nM
For compound 4 the middle estimate is 1.1-fold (0.03 log units) below the measured one, within the range that was stated.
By their numbers in this assay, from the lowest: compounds 3, 4 and 1 (each within the scatter of the next); then compound 2.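

In this assay, the series now has its first counted step at this position: with the rest of the structure unchanged, (4-chloro-3-(trifluoromethyl)phenyl)amino in place of 4-chloro-3-(trifluoromethyl)phenyl on the carbonyl carbon gives a 2.6-fold lower number from compound 2 to compound 4 (0.41 log units; beyond the scatter), a modest change. The earlier compounds shown here offered only an indirect comparison, mixed with differences in the core, whereas this pair isolates the change: the aromatic ring and its substituents stay, and the entering group adds one nitrogen and one hydrogen-bond donor. Nothing measured alongside this pair bears on what lies behind the step.

From the compounds shown here alone, whether the nitrogen itself matters, or only the longer link to the ring, stays open, and a methylene or a methylamino group on the carbonyl carbon would be the group to set against the amino group here. Also open is whether the step carries over to another core, such as that of compound 1, since the compounds shown hold no matching pair for it there.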